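Swapping hydroxy for chloro on the aryl ketone

This account rests on a few compounds, and the source may have more. Where it says the series, first, only, none or still open, it means among the compounds named here.

Measured in an ADME assay on OVCAR-5 cells (Homo sapiens) for cytotoxicity, read by sulforhodamine B assay, with a stated time of 24 h; a lower number here means that less compound is tolerated, a higher number that more compound is tolerated:
compound 1 `COc1ccc(C(=O)/C=C/c2cc3ccccc3[nH]c2=O)cc1` gives > 100000 nM, which is a limit of the assay.
compound 2 `O=C(/C=C/c1cc2ccccc2[nH]c1=O)c1ccc(O)cc1` gives 44400 nM.

Within the data shown here, compound 2 holds the only number measured; the other value is a limit, (the limit of > 100000 nM in this assay, at which 1 of the 2 values shown sits). Among the measured compounds shown here, the one measured change is an at least 2.2-fold lower number from compound 1 to compound 2 (0.35 log units; beyond the scatter). Compound 3 `O=C(/C=C/c1cc2ccccc2[nH]c1=O)c1ccc(Cl)cc1` differs from compound 2 by chloro in place of hydroxy on an aromatic carbon. For the measured compounds named here, no measured step covers chloro in place of hydroxy, and the measured step concerned a different replacement, so it gives no direction for this one. Compound 3 is therefore expected to show a step of a 1.1-fold higher number from compound 2 to compound 3 (0.05 log units; within the scatter) that stays within the scatter. The estimate for compound 3 is 50000 nM, with a range from 20000 nM to 150000 nM.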

Compound 3, concentration lethal to 50% of the cells: > 100000 nM
Compound 3 gave a limit, no number; the forecaster's own chance of this, stated with the estimate: 30%; at least 2.0-fold (0.30 log units) between middle value and limit.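

Putting chloro in place of hydroxy at this position on the aromatic ring gives an at least 2.2-fold higher number from compound 2 to compound 3 (0.35 log units; beyond the scatter) in this assay, so this change moves the result beyond the scatter. Going by these compounds, compound 3 gives a limit rather than a number, so the full size of that step stays unknown. The step between compound 1 and compound 3 cannot be read, and the limit is now shared: the limit of > 100000 nM in this assay, at which 2 of the 3 values shown sit.

Among the compounds shown, only the one with hydroxy at this position gives a number. On these data alone, whether an amine or a carboxylic acid there would also give a number remains open.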